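From a Sulfonic Acid Chain to a Piperidine Tail

The compounds below may be only part of what the source reports. "The series", "measured", "known", "first", "only" and "open" are said of these compounds alone.

Within the data shown here, compound 2 `COc1cc(N)c(Cl)cc1C(=O)NC1CCN(CCCCCCCCS(=O)(=O)O)CC1` gives 1000 nM in a functional assay on HEK293 cells for agonist activity at 5-hydroxytryptamine receptor 4 (Homo sapiens), read by cAMP accumulation (on this read-out lower numbers stand for an effect already at smaller amounts and higher numbers for an effect only at larger amounts of compound), and stands highest of the two numbers so far, while compound 1 `CCCCCN1CCC(NC(=O)c2cc(Cl)c(N)cc2OC)CC1` gives 25.1 nM in this assay. Compound 3 `COc1cc(N)c(Cl)cc1C(=O)NC1CCN(CCN2CCCCC2)CC1` differs from compound 2 by piperidin-1-yl in place of 6-sulfohexyl on a saturated chain carbon, two bonds along the chain from an amine nitrogen in a ring. Among the measured compounds shown here, only one measured step bears on this: because a 40-fold higher number from compound 1 to compound 2 (1.60 log units; beyond the scatter) was large and came with the 3-sulfopropyl addition, removing the 6-sulfohexyl in compound 3 is expected to bring the number down strongly. Compound 3 is estimated at 30 nM, with a range from 5 nM to 200 nM. The expected step is a 33-fold lower number from compound 2 to compound 3 (1.52 log units; beyond the scatter).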

Compound 3, half-maximal effective concentration: 100 nM
For compound 3 the middle estimate is 3.3-fold (0.52 log units) below the measured one, within the range that was stated.
By their numbers in this assay, from the lowest: compound 1; then compound 3; then compound 2.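

In this assay, piperidin-1-yl in place of 6-sulfohexyl gives a 10-fold lower number from compound 2 to compound 3 (1.00 log units; beyond the scatter), so a ring on this chain is better accommodated than the long sulfonic acid chain. The same ring in place of propyl still gives a 4.0-fold higher number from compound 1 to compound 3 (0.60 log units; beyond the scatter), so compound 3 recovers only part of the ground lost with compound 2. Nothing measured here accounts for either step. On these data alone, it remains open whether a morpholine ring or an open-chain amine in this place would reach the number of compound 1. A carboxylic acid on a shorter chain also remains an open case.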